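The compounds below may be only part of what the source reports. "The series", "measured", "known", "first", "only" and "open" are said of these compounds alone.

Compound 2 `N#CC1=C(/N=C/c2ccc([N+](=O)[O-])cc2[N+](=O)[O-])N(c2ccc(S(N)(=O)=O)cc2)C2=C(C(=O)CCC2)C1c1ccc(Cl)cc1Cl` gives 20% in a functional assay on Ehrlich cells (Mus musculus) for cytotoxicity, read by trypan blue exclusion, with a stated time of 2 h, tested at 100 ug/mL (a higher number here means a stronger effect of the compound at the concentration tested, a lower number a weaker effect), standing level with compound 1 `CN(C)c1ccc(/C=C/C=N/C2=C(C#N)C(c3ccc(Cl)cc3Cl)C3=C(CCCC3=O)N2c2ccc(S(N)(=O)=O)cc2)cc1`, which gives 20% in the same assay. Compound 3 `CCO/C=N/C1=C(C#N)C(c2ccc(Cl)cc2Cl)C2=C(CCCC2=O)N1c1ccc(S(N)(=O)=O)cc1` differs from compound 2 by ethoxy in place of 2,4-dinitrophenyl on a carbon with a double bond to nitrogen. For the measured compounds named here, the one step already known at this carbon with a double bond to nitrogen, no change at the digits printed from compound 1 to compound 2 (within the scatter), exchanged the group there and stayed within the scatter, so a further exchange at the same place is expected to leave the read-out close to where it is. Compound 3 is therefore estimated at 20%, between 8% and 32%, an expected step of no change at the digits printed from compound 2 to compound 3 (within the scatter).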

Compound 3, a percentage reported as activity, at one concentration (the size of the read-out at that concentration, not a potency): 40%
For compound 3 the middle estimate is 20 percentage points below the measured one, and the stated range ends below it.
By their numbers in this assay, from the lowest: compounds 1 and 2 (each within the scatter of the next); then compound 3.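

In this assay, the carbon with a double bond to nitrogen proves able to move the read-out: ethoxy in place of 2,4-dinitrophenyl gives a number 20 percentage points higher from compound 2 to compound 3 (beyond the scatter) and ethoxy in place of 2-(4-(dimethylamino)phenyl)ethenyl gives a number 20 percentage points higher from compound 1 to compound 3 (beyond the scatter). For the compounds shown here, the exchange between the two larger groups had stayed within the scatter, so the smaller ethoxy is the first group here to stand apart. Nothing measured here accounts for this rise. The compounds shown leave open how a longer alkoxy chain such as butoxy, or an amine, would read at this place.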